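Furan-3-yl Added to a Phenoxyhexanoate Amide

This account rests on a few compounds, and the source may have more. Where it says the series, first, only, none or still open, it means among the compounds named here.

In an ADME assay on HepG2 cells (Homo sapiens) for cytotoxicity, read by CellTiter-Glo and resazurin assay, with a stated time of 72 h (on this read-out higher numbers stand for an effect only at larger amounts of compound and lower numbers for an effect already at smaller amounts), compound 1 `CC(C)N(Cc1cccc(OCCCCCC(=O)O)c1)C(=O)c1ccccc1` gives > 26000 nM, which is a limit of the assay and not a number. Compound 2 `CC(C)N(Cc1cccc(OCCCCCC(=O)O)c1)C(=O)c1ccc(-c2cccc(Br)c2)cc1` gives > 26000 nM, again a limit. Compound 3 `CCOC(=O)CCCCCOc1cccc(CN(C(=O)c2ccccc2)C(C)C)c1` gives > 26000 nM, likewise a limit.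

Compound 3 therefore stands at the limit of this assay, and the two other values shown sit at the same limit, so nothing separates the three compounds on this read-out. The step that the two limits leave unreadable from compound 1 to compound 2 cannot be read, and the step that the two limits leave unreadable from compound 1 to compound 3 cannot be read either, because of the limit of > 26000 nM in this assay, at which 3 of the 3 values shown sit.

Compound 4 `CCOC(=O)CCCCCOc1cccc(CN(C(=O)c2ccc(-c3ccoc3)cc2)C(C)C)c1` differs from compound 3 by furan-3-yl in place of hydrogen on an aromatic carbon. For the measured compounds named here, the nearest measured step is the one from compound 1 to compound 2, where an aromatic ring entered at the same kind of place, yet its size is not readable. With every value at the limit, no step beyond the scatter can be expected in this assay in either direction, and the most likely outcome for compound 4 is again a limit. Compound 4 is therefore estimated at 26000 nM, between 10000 nM and 60000 nM, which means an expected step of a number no higher from compound 3 to compound 4 (the limit leaves the size open).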

Compound 4, half-maximal effective concentration: > 26000 nM
Compound 4 gave a limit, no number; the forecaster's own chance of this, stated with the estimate: 70%; the middle value lies on the limit itself.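

In this assay compound 4 gives > 26000 nM, again a limit and not a number. No new step can be read between compound 3 and compound 4, because both stand at the same limit: the limit of > 26000 nM in this assay, at which 4 of the 4 values shown sit.

The compounds shown leave open whether furan-3-yl or 3-bromophenyl changes the effect on these cells at all.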